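Aminoquinoline hydrazone series: replacing the dinitrophenyl terminus

The source may hold more compounds than are shown below. What is called first, only, known or untested is meant among the compounds shown, and "the series" means these compounds.

The three measured compounds share one core and differ only in the aryl group on the terminal amine nitrogen. Compound 1 `O=C(/C=N/Nc1ccc([N+](=O)[O-])cc1[N+](=O)[O-])NCCCCCCCNc1ccnc2cc(Cl)ccc12` carries the dinitrophenyl group and in a functional assay on MRC5 cells (Homo sapiens) for cytotoxicity, read by colorimetric assay and MTT assay (a lower number here means that less compound is tolerated, a higher number that more compound is tolerated), gives 11100 nM. This is the highest of the three numbers, so compound 1 is the best tolerated of the set. Compound 2 `O=C(/C=N/Nc1ccnc2cc(Cl)ccc12)NCCCCCCCNc1ccnc2cc(Cl)ccc12` gives 1400 nM in this assay, and compound 3 `Cc1cc(N/N=C/C(=O)NCCCCCCCNc2ccnc3cc(Cl)ccc23)nc2c1c(C)nn2C` gives 1800 nM. Both replacements of the dinitrophenyl group by a heteroaromatic system lower the number beyond the scatter: the step of a 7.9-fold lower number from compound 1 to compound 2 (0.90 log units; beyond the scatter) and the step of a 6.2-fold lower number from compound 1 to compound 3 (0.79 log units; beyond the scatter). The two heteroaromatic variants themselves are close, as the step of a 1.3-fold higher number from compound 2 to compound 3 (0.11 log units; within the scatter) shows.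

Compound 4 `COc1ccc2nc(N/N=C/C(=O)NCCCCCCCNc3ccnc4cc(Cl)ccc34)nnc2c1` differs from compound 1 by a group of 12 heavy atoms (8 carbon, 3 nitrogen, 1 oxygen; one six-membered aromatic ring of carbon only, one six-membered aromatic ring with 3 hetero atoms) in place of a group of 12 heavy atoms (6 carbon, 2 nitrogen, 4 oxygen; one six-membered aromatic ring of carbon only), on an amine nitrogen. This change is of the same kind as the two measured steps away from compound 1: a fused bicyclic heteroaromatic group enters on the amine nitrogen in place of the dinitrophenyl group. On that basis a modest lowering of the number in this assay is expected for compound 4, a 5.6-fold lower number from compound 1 to compound 4 (0.74 log units; beyond the scatter), with no ground in the data to expect a different direction. Compound 4 is estimated at 2000 nM, with a range from 800 nM to 6000 nM.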

Compound 4, half-maximal cytotoxic concentration: 2500 nM
For compound 4 the middle estimate is 1.3-fold (0.10 log units) below the measured one; the measured number falls inside the stated range.
By their numbers in this assay, from the lowest: compounds 2, 3 and 4 (each within the scatter of the next); then compound 1.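

Working notes on the terminal aryl group. In this assay, a third replacement of 2,4-dinitrophenyl on the amine nitrogen, this time with one six-membered aromatic ring of carbon only and one six-membered aromatic ring with 3 hetero atoms, again falls beyond the scatter (a 4.4-fold lower number from compound 1 to compound 4 (0.65 log units; beyond the scatter)), so all three replacements shown lie below compound 1 and none of them goes against this. The new group also cannot be told apart from the other two replacements (a 1.4-fold higher number from compound 3 to compound 4 (0.14 log units; within the scatter); a 1.8-fold higher number from compound 2 to compound 4 (0.25 log units; within the scatter)), so among these three groups the different ring sizes, hetero atom counts and the swap of chlorine for oxygen leave no readable difference at this position. Nothing measured on these compounds accounts for the gap between compound 1 and the other three.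

From the compounds shown here alone, it stays open whether the higher number of compound 1 depends on the two nitro groups or on the single carbocyclic ring, which a phenyl group carrying one nitro group, or plain phenyl, would help to separate. Going by these compounds, it is equally open how a terminal group bearing an amine or a carboxylic acid would read here, and whether the pattern holds with a longer chain.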